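Swapping Ethoxy for Fluoro in a Cytotoxicity Series

A few compounds are considered here, and "the series" means these few. Any claim that something is new, unique, unknown or untested is made for them only; others in the source may bear on it.

Compound 2 `CCOc1ccc2nc(Nc3nc4ccc(F)cc4s3)sc2c1` was tested in a functional assay on THP-1 cells (Homo sapiens) for cytotoxicity, read by MTT assay, with a stated time of 48 h (a higher number here means a weaker inhibitor, a lower number a stronger inhibitor), and gives 39000 nM. Of the two compounds with a number, compound 2 has the highest, yet its nearest neighbour, compound 3 `CCOc1ccc2nc(Nc3nc4ccccc4s3)sc2c1`, gives 37100 nM, and the gap of a 1.1-fold lower number from compound 2 to compound 3 (0.02 log units; within the scatter) lies within the scatter, so the two cannot be put in order. Compound 1 `Fc1ccc2nc(Nc3nc4ccccc4s3)sc2c1` reached only the assay's limit, at > 50000 nM; > 50000 nM (2 entries) in two runs. Compound 4 `Fc1ccc2nc(Nc3nc4ccc(F)cc4s3)sc2c1` has not yet been measured; it differs from compound 2 as follows: fluoro in place of ethoxy on an aromatic carbon. Among the compounds with values here, no measured step covers this exact change. The closest comparison is compound 3 against compound 1, which differ in the same way: compound 3 gives a number, whereas compound 1 reaches only the limit. The step from compound 2 to compound 4 in this assay is therefore expected to raise the number, by roughly a 1.7-fold higher number from compound 2 to compound 4 (0.22 log units; within the scatter), and quite possibly beyond what the assay can report. Compound 4 is expected to give about 65000 nM in this assay, within a range from 30000 nM to 150000 nM.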

Compound 4, half-maximal inhibitory concentration: 17500 nM
Beside the measured number, compound 4's estimate is 3.7-fold (0.57 log units) above it; the whole stated range lies above it.
By their numbers in this assay, from the lowest: compound 4; then compounds 3 and 2 (each within the scatter of the next).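

In this assay, putting fluoro in place of ethoxy at this position brings a modest but real change, with a 2.2-fold lower number from compound 2 to compound 4 (0.35 log units; beyond the scatter). Compound 1 makes the same swap on a molecule without the second fluoro, and its > 50000 nM; > 50000 nM (2 entries) is a limit of the assay, not a number. Its ethoxy partner, compound 3, gives 37100 nM, so without the second fluoro the swap moves the number the opposite way, and the outcome of this change depends on what the rest of the molecule carries.

Nothing measured here explains why the same swap behaves differently in the two pairs. Going by these compounds, it also remains open whether an amine, a methoxy group or a longer chain at this position would lower the number further.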